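The source may report more compounds than this note shows. Statements on the series, on what has been measured and on what is new or still open speak of the compounds shown alone.

Measured compounds:
- compound 1 `COc1ccc(N2C(=O)[C@H]3[C@H](ON4[C@@H]3C(=O)N(C)[C@@]43C[C@H](C)CC[C@H]3C(C)C)C2=O)cc1`: 48.9%
- compound 2 `Cc1ccc(N2C(=O)[C@H]3[C@H](ON4[C@@H]3C(=O)N(C)[C@@]43C[C@H](C)CC[C@H]3C(C)C)C2=O)c(C)c1`: 52.9%

In a functional assay, read by spectrophotometry, with a stated time of 2 h, tested at 0.5 mg/mL (on this read-out lower numbers stand for a weaker effect and higher numbers for a stronger effect at the one concentration tested), compound 1 gives 48.9% and compound 2 gives 52.9%. Among the compounds with values here, the only step between them, a number 4 percentage points higher from compound 1 to compound 2 (within the scatter), lies within the scatter, so compound 2 cannot be set apart from compound 1; the two numbers agree as far as this assay can tell.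

Compound 3 `CC(C)[C@@H]1CC[C@@H](C)C[C@@]12N(C)C(=O)[C@@H]1[C@H]3C(=O)N(c4ccc5ccccc5c4)C(=O)[C@H]3ON12` is not yet measured. It differs from compound 2 in one place: naphthalen-2-yl in place of 2,4-dimethylphenyl on an amide-type nitrogen in a ring. Within the data shown here, the one measured step that bears on this change is the exchange of the aromatic group on the same amide-type nitrogen in a ring, a number 4 percentage points higher from compound 1 to compound 2 (within the scatter), which stayed within the scatter. On that basis the expected step is a number 0.9 percentage points lower from compound 2 to compound 3 (within the scatter), that is, no change beyond the scatter in either direction. Compound 3 is therefore estimated at 52%, with a range from 38% to 66%.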

Compound 3, a percentage reported as activity, at one concentration (the size of the read-out at that concentration, not a potency): 25.4%
Compound 3: the middle estimate sits 26.6 percentage points above what was measured; the whole stated range lies above it.
By their numbers in this assay, from the lowest: compound 3; then compounds 1 and 2 (each within the scatter of the next).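

In this assay, the group on this amide-type nitrogen in a ring can clearly affect the read-out: naphthalen-2-yl gives a number 27.5 percentage points lower from compound 2 to compound 3 (beyond the scatter) and a number 23.5 percentage points lower from compound 1 to compound 3 (beyond the scatter). Within the data shown here, the two groups with one six-membered aromatic ring could not be set apart, so this is the first change here to go beyond the scatter, and it brings in a second aromatic ring. Nothing measured here explains the drop.

Among these compounds, whether the second ring itself matters, or only this way of joining it to the nitrogen, remains open, since only one two-ring group appears. Plain phenyl, naphthalen-1-yl, or a pyridine ring in this place would help to separate those possibilities, and a carboxylic acid or an amine on the aromatic ring would test a different kind of group.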